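Restoring a sulfonamide linker in a chemokine receptor series

This account rests on a few compounds, and the source may have more. Where it says the series, first, only, none or still open, it means among the compounds named here.

Measured compounds:
compound 1, `CC[C@H]1CN(c2nc(N)c(C(=O)NCCNS(N)(=O)=O)nc2Cl)CCN1C1CCN(Cc2ccc(Cl)cc2)CC1`: 1.9 nM
compound 2, `CC[C@H]1CN(c2nc(N)c(C(=O)NCCS(C)(=O)=O)nc2Cl)CCN1C1CCN(Cc2ccc(Cl)cc2)CC1`: 6.4 nM

In an in vitro assay on BaF3 cells for displacement of a labelled ligand from C-X-C chemokine receptor type 3 (Homo sapiens) (on this read-out lower numbers stand for stronger inhibition and higher numbers for weaker inhibition), compound 2 gives the highest number of the two and stands nearest compound 1, the step being a 3.4-fold higher number from compound 1 to compound 2 (0.53 log units; beyond the scatter). That step exchanged the sulfamoylamino group of compound 1 for the methylsulfonyl group of compound 2.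

Compound 3, `CC[C@H]1CN(c2nc(N)c(C(=O)NCCNS(C)(=O)=O)nc2Cl)CCN1C1CCN(Cc2ccc(Cl)cc2)CC1`, has not yet been measured. The change is methanesulfonamido in place of methylsulfonyl on a saturated chain carbon, two bonds along the chain from an amide-type nitrogen. Methanesulfonamido brings back the nitrogen-linked sulfonyl arrangement of compound 1 while keeping the methyl of compound 2, so compound 3 sits between the two measured structures. For the measured compounds named here, the only step that bears on it is a 3.4-fold higher number from compound 1 to compound 2 (0.53 log units; beyond the scatter), which went in the weaker direction. Compound 3 is therefore expected to move back part of the way, a 2.0-fold lower number from compound 2 to compound 3 (0.30 log units; within the scatter), and its value in this assay is estimated at 3.2 nM within a range of 1.3 nM to 8 nM.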

Compound 3, half-maximal inhibitory concentration: 4.4 nM
Beside the measured number, compound 3's estimate is 1.4-fold (0.14 log units) below it; the range from low to high includes it.
By their numbers in this assay, from the lowest: compound 1; then compounds 3 and 2 (each within the scatter of the next).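

In this assay, exchanging methylsulfonyl for methanesulfonamido at this position gives a 1.5-fold lower number from compound 2 to compound 3 (0.16 log units; within the scatter), so the added nitrogen, with its one hydrogen-bond donor, makes no difference that can be told apart from scatter. The clearer difference lies on the sulfonyl sulfur: methyl in place of amino gives a 2.3-fold higher number from compound 1 to compound 3 (0.36 log units; beyond the scatter), so compound 1 keeps a modest edge over compound 3 even though both carry the nitrogen-linked sulfonyl arrangement. Nothing available gives a reason for either step.

The compounds shown leave open how the number responds to other groups on the sulfonyl sulfur, such as ethyl or dimethylamino. They also leave open whether the sulfonyl is needed at all, which a carboxylic acid or a simple acetamide at the chain end would test, and how a longer chain would fare.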